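Methoxy for dimethylamino on a fused bile acid transporter scaffold

The compounds below may be only part of what the source reports. "The series", "measured", "known", "first", "only" and "open" are said of these compounds alone.

Of the compounds shown here, three sharing one core have been tested in an assay on cells for inhibition of ileal sodium/bile acid cotransporter (Homo sapiens); a lower number here means a stronger inhibitor, a higher number a weaker inhibitor. Compound 1 `CCCCC1(CCCC)CS(=O)(=O)c2cc(OC)ccc2[C@@H](c2ccccc2)[C@H]1O` gives 190 nM. Compound 3 `CCCCC1(CCCC)CS(=O)(=O)c2cc(N(C)C)ccc2[C@@H](c2ccccc2)[C@H]1O` gives 120 nM. Compound 2 `CCCCC1(CCCC)CS(=O)(=O)c2ccc(N(C)C)cc2[C@@H](c2ccc(F)cc2)[C@H]1O` gives 10 nM, the lowest number of the three; its gap to compound 3 and to compound 1 lies beyond the scatter. The difference between the cores of compound 2 and compound 3 is not broken down here.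

Compound 4 `CCCCC1(CCCC)CS(=O)(=O)c2ccc(OC)cc2[C@@H](c2ccc(F)cc2)[C@H]1O` is not yet measured. It is obtained from compound 2 by the change (methoxy in place of dimethylamino on an aromatic carbon). The same change links compound 3 to compound 1, (methoxy in place of dimethylamino on an aromatic carbon), and there it produced a 1.6-fold higher number from compound 3 to compound 1 (0.20 log units; within the scatter). Because that step was a 1.6-fold higher number from compound 3 to compound 1 (0.20 log units; within the scatter), the expected step from compound 2 to compound 4 is a comparably small one, a 1.6-fold higher number from compound 2 to compound 4 (0.20 log units; within the scatter). On that basis, compound 4 is estimated in this assay at 16 nM, with a plausible range from 7 nM to 35 nM.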

Compound 4, half-maximal inhibitory concentration: 50 nM
Compound 4: middle estimate off by 3.1-fold (0.49 log units), on the low side; measured number outside the range, above it.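

In this assay, putting methoxy in place of dimethylamino gives a 5.0-fold higher number from compound 2 to compound 4 (0.70 log units; beyond the scatter), and the change does not carry over at the same size from one core to the other: the same change on two cores in this assay, a 1.6-fold higher number (0.20 log units; within the scatter) from compound 3 to compound 1 and a 5.0-fold higher number (0.70 log units; beyond the scatter) from compound 2 to compound 4, 3.2-fold (0.50 log units) apart, beyond the scatter of two such steps

The number rises clearly only on the core of compound 2, while the step on the core of compound 3 stays within the scatter, so these two pairs do not establish a shared direction for the change. The two cores differ in more than one place, and nothing shown separates those differences, so the data do not say which of them governs the size of the step or why it differs.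

As far as these compounds go, it remains open whether the larger step would persist on a core that carries only one of those differences. From the compounds shown here alone, it is also open how other groups on the same aromatic carbon, such as a primary amine, an ethoxy group or a carboxylic acid, would compare with dimethylamino and methoxy on either core.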